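Removing a Methoxy Group from a Dichloroacetamide Biaryl

The source may hold more compounds than are shown below. What is called first, only, known or untested is meant among the compounds shown, and "the series" means these compounds.

Of the compounds shown here, three have been tested in a functional assay on A549 cells (Homo sapiens) for cytotoxicity, read by MTT assay, with a stated time of 68 h; a lower number here means a stronger inhibitor, a higher number a weaker inhibitor. Compound 1 `COc1ccc(-c2cc(NC(=O)C(Cl)Cl)cc(-c3ccc(OC)cc3)c2)cc1` gives 20800 nM, compound 3 `COc1ccccc1-c1cc(NC(=O)C(Cl)Cl)cc(-c2ccccc2OC)c1` gives 25500 nM, and compound 2 `COc1ccc(-c2cccc(NC(=O)C(Cl)Cl)c2)cc1` gives 8530 nM, the lowest of the three numbers. Among the compounds with values here, the only single-point step measured so far, a 2.4-fold lower number from compound 1 to compound 2 (0.39 log units; beyond the scatter), removed a whole 4-methoxyphenyl group. Compound 4 `O=C(Nc1cccc(-c2ccccc2)c1)C(Cl)Cl` differs from compound 2 by a smaller change: hydrogen in place of methoxy on an aromatic carbon. Within the data shown here, no measured step removes a methoxy alone, so the earlier step is only a loose guide, and the direction of this change cannot be read from the data. Compound 4 is therefore expected to land close to compound 2, with a 1.1-fold higher number from compound 2 to compound 4 (0.02 log units; within the scatter) likely within the scatter. The estimate for compound 4 is 9000 nM, with a range from 3500 nM to 25000 nM.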

Compound 4, half-maximal inhibitory concentration: 8900 nM
Compound 4: the middle estimate sits 1.0-fold (0.00 log units) above what was measured; low and high end bracket the measured number.
By their numbers in this assay, from the lowest: compounds 2 and 4 (each within the scatter of the next); then compounds 1 and 3 (each within the scatter of the next).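

With hydrogen in place of methoxy, para to a large group, this assay shows a 1.0-fold higher number from compound 2 to compound 4 (0.02 log units; within the scatter). The earlier compounds had shown only the loss of a whole 4-methoxyphenyl group; this step shows that, between compound 2 and compound 4, the methoxy alone leaves the number within the scatter. Nothing measured here accounts for this result. The compounds shown leave open whether an amine, a carboxylic acid or a longer chain at this position would shift the number, and whether the same exchange would behave alike on compound 1.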